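Swapping the Bicyclic Ring on the Sulfonyl Sulfur

A few compounds are considered here, and "the series" means these few. Any claim that something is new, unique, unknown or untested is made for them only; others in the source may bear on it.

Compound 1 `CCN(Cc1ccccc1)C(=O)C1CCN(S(=O)(=O)c2ccccc2OC)CC1` and compound 2 `CCN(Cc1ccccc1)C(=O)C1CCN(S(=O)(=O)c2cccnc2)CC1` share a core with compound 3 `CCN(Cc1ccccc1)C(=O)C1CCN(S(=O)(=O)c2ccc3cccnc3c2)CC1`, differing only in the group attached to the sulfonyl sulfur. Within the data shown here, in a functional assay on CHO cells for positive allosteric modulation of muscarinic acetylcholine receptor M5 (Homo sapiens), read by calcium flux (on this read-out higher numbers stand for larger maximal responses and lower numbers for smaller maximal responses), compound 1 gives "not determined" (no result reported) and compound 2 gives "not determined" (no result reported), so compound 3, which reaches 66%, holds the only number in this set. Compound 4 `CCN(Cc1ccccc1)C(=O)C1CCN(S(=O)(=O)c2ccc3[nH]ncc3c2)CC1` carries 1H-indazol-5-yl in place of quinolin-7-yl on a sulfonyl sulfur. Among the measured compounds shown here, no step between two measured compounds is available to guide this change, so any expectation rests on compound 3 alone. The expected step of a number 6 percentage points lower from compound 3 to compound 4 (within the scatter) is small, not clearly beyond the usual scatter. Compound 4 is therefore estimated to reach 60% in this assay, with a range from 35% to 85%.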

Compound 4, largest response reached (reported as percent of maximum), in percent of the reference or control that the assay uses: 86%
Compound 4: the middle estimate sits 26 percentage points below what was measured; measured number outside the range, above it.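

In this assay the sulfonyl sulfur position shows a real response to the ring attached there: 1H-indazol-5-yl in place of quinolin-7-yl gives a number 20 percentage points higher from compound 3 to compound 4 (beyond the scatter). The group need not be quinolin-7-yl to give a large maximal response, and a bicyclic group with a five-membered ring and a hydrogen-bond donor is accepted. No measurement available here accounts for the gain. With no numbers for compound 1 and compound 2, simpler single-ring groups cannot be judged. On these data alone, whether the indazole hydrogen matters remains open, and a methyl group on that nitrogen would test it.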